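Para substituent survey on the benzylamine arm of the quinazoline series

The compounds below may be only part of what the source reports. "The series", "measured", "known", "first", "only" and "open" are said of these compounds alone.

Of the compounds shown here, three have been measured in an assay for inhibition of high affinity nerve growth factor receptor (Homo sapiens), read by HTRF, with a stated time of 30 min, in the presence of a further agent that is not named here; on this read-out higher numbers stand for weaker inhibition and lower numbers for stronger inhibition. Compound 1 `Cc1cc(Nc2nc(NCc3ccc(F)cc3)nc3ccccc23)n[nH]1` gives 20 nM. Compound 2 `Cc1cc(Nc2nc(NCc3ccc(Br)cc3)nc3ccccc23)n[nH]1` gives 180 nM. Compound 3 `Cc1cc(Nc2nc(NCc3ccc(C#N)cc3)nc3ccccc23)n[nH]1` gives 83 nM. On these numbers compound 3 stands second highest of the three: the nearest neighbour is compound 2, the furthest compound 1. The steps among the measured compounds are all single swaps at the same aromatic carbon: a 9.0-fold higher number from compound 1 to compound 2 (0.95 log units; beyond the scatter), a 4.2-fold higher number from compound 1 to compound 3 (0.62 log units; beyond the scatter) and a 2.2-fold lower number from compound 2 to compound 3 (0.34 log units; beyond the scatter).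

Compound 4 `Cc1cc(Nc2nc(NCc3ccc(C(F)(F)F)cc3)nc3ccccc23)n[nH]1` is the next member and awaits measurement in this assay. It differs from compound 3 by trifluoromethyl in place of cyano on an aromatic carbon. For the measured compounds named here, no measured step involves trifluoromethyl, so the two steps that end at the cyano compound are the ones that bear on it: the cyano compound sits between the fluoro and bromo compounds, with a 4.2-fold higher number from compound 1 to compound 3 (0.62 log units; beyond the scatter) and a 2.2-fold lower number from compound 2 to compound 3 (0.34 log units; beyond the scatter). Every swap at this carbon so far has moved the number by a modest amount beyond the scatter, in either direction. For compound 4 a modest rise is expected, of about a 1.8-fold higher number from compound 3 to compound 4 (0.26 log units; within the scatter), since the group entering is larger than the cyano it replaces. Compound 4 is therefore estimated at 150 nM, with a range of 40 nM to 500 nM.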

Compound 4, half-maximal inhibitory concentration: 1400 nM
For compound 4 the middle estimate is 9.3-fold (0.97 log units) below the measured one, and the stated range ends below it.
By their numbers in this assay, from the lowest: compound 1; then compound 3; then compound 2; then compound 4.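

In this assay trifluoromethyl gives the first large step seen at this aromatic carbon with a 17-fold higher number from compound 3 to compound 4 (1.23 log units; beyond the scatter) and the number also rises beyond the scatter with a 7.8-fold higher number from compound 2 to compound 4 (0.89 log units; beyond the scatter) and with a 70-fold higher number from compound 1 to compound 4 (1.85 log units; beyond the scatter). The spread among fluoro, cyano and bromo therefore understated how far a single swap at this carbon can move the number, and the order from the lowest number is now fluoro, cyano, bromo, trifluoromethyl across these four compounds only. No measurement at hand on these compounds speaks to the origin of the rise from cyano to trifluoromethyl.

As far as these compounds go, whether the rise is peculiar to trifluoromethyl stays open, and a methyl, chloro, methoxy or amine group at this same carbon would show whether the numbers climb steadily or break sharply at that one group. Also open, from the compounds shown here alone, is whether the swap from cyano to trifluoromethyl carries the same cost on another carbon of this ring or with a different group on the shared core.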